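The compounds below may be only part of what the source reports. "The series", "measured", "known", "first", "only" and "open" are said of these compounds alone.

Compound 1 (`COc1cccc(OC)c1C(=O)Nc1c[nH]nc1C(=O)NN1CCOCC1`) gives > 50000 nM in an ADME assay on MRC5 cells (Homo sapiens) for inhibition, with a stated time of 72 h (a higher number here means that more compound is needed for the effect, a lower number that less compound is needed), and this is a limit of the assay, not a number. Compound 2 (`CO[C@H]1CC[C@H](NC(=O)c2n[nH]cc2NC(=O)c2ccccc2)CC1`) gives 800 nM and compound 3 (`COc1cccc(OC)c1C(=O)Nc1c[nH]nc1C(=O)NCc1ccccc1`) gives 50000 nM as the higher of these two numbers. Compound 4 (`COc1cccc(OC)c1C(=O)Nc1c[nH]nc1C(=O)NCCCN(C)C`) has yet to be measured and departs from compound 3 by a single change (2-(dimethylamino)ethyl in place of phenyl on a saturated chain carbon bound to an amide-type nitrogen) that, cut one bond further out, reads benzyl to 3-(dimethylamino)propyl. Among the compounds with values here, the one measured step that bears on it (a number no higher from compound 1 to compound 3 (the limit leaves the size open)) also replaces a group on an amide-type nitrogen. As far as these compounds go, its size stays open because of the limit of > 50000 nM in this assay, at which 1 of the 3 values shown sits, and it offers a direction only. Within the data shown here, with compound 3 at 50000 nM as the only number to start from, no shift beyond the scatter is expected in this assay for this change. The expected step (a 1.4-fold lower number from compound 3 to compound 4 (0.15 log units; within the scatter)) is therefore small. For compound 4 the estimate is 35000 nM with an expected range from 10000 nM to 60000 nM in this measurement.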

Compound 4, half-maximal effective concentration: > 50000 nM
Compound 4 gave a limit, no number; the forecaster's own chance of this, stated with the estimate: 40%; at least 1.4-fold (0.15 log units) between middle value and limit.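

The change from benzyl to 3-(dimethylamino)propyl on the amide-type nitrogen gives, in this assay, a number no lower from compound 3 to compound 4 (the limit leaves the size open). An open chain carrying a dimethylamino nitrogen therefore does not lower the number relative to benzyl, something the earlier step from the morpholin-4-yl compound, which ran only in the opposite direction, could not show. Neither the size of this step nor the step between compound 1 and compound 4 can be read, because of a limit of the assay: the limit of > 50000 nM in this assay, at which 2 of the 4 values shown sit.

The compounds shown leave open whether any group on this amide-type nitrogen brings the number down on the shared core of compound 3. A carboxylic acid, a primary amine on a shorter chain or a piperazine at that place would address this.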